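A few compounds are considered here, and "the series" means these few. Any claim that something is new, unique, unknown or untested is made for them only; others in the source may bear on it.

In a functional assay on HepG2 cells (Homo sapiens) for inhibition, read by MTT assay, with a stated time of 24 h (a higher number here means a weaker inhibitor of growth, a lower number a stronger inhibitor of growth), three compounds have been measured. Compound 1 `COc1cccc(C(=O)n2c(-c3cn(C)c4ccccc34)nc3ccccc32)c1` gives 13600 nM. Compound 2 `COc1ccc(C(=O)n2c(-c3cn(C)c4ccccc34)nc3ccccc32)cc1OC` gives 8400 nM. Compound 3 `COc1ccc2c(c1)c(-c1nc3ccccc3n1C(=O)c1ccccc1)cn2C` gives 37900 nM, the highest of the three numbers.

Compound 1 and compound 2 differ in one place, (methoxy in place of hydrogen on an aromatic carbon), and this gave a 1.6-fold lower number from compound 1 to compound 2 (0.21 log units; within the scatter). Compound 3 is built from the same atoms as compound 1, joined differently; the difference between the two cores is not broken down here. Compound 3 stands beyond the scatter from both compound 1 and compound 2.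

Compound 4 `COc1ccc2c(c1)c(-c1nc3ccccc3n1C(=O)c1ccccc1OC)cn2C` has not yet been measured in this assay. It differs from compound 3 by methoxy in place of hydrogen on an aromatic carbon. Going by the values given here, this is the same kind of change as the one from compound 1 to compound 2, but not the same: in compound 2 the new methoxy sits ortho to a methoxy group and para to a large group, whereas in compound 4 it sits ortho to a large group.

Among the compounds with values here, the only measured step of this kind is within the scatter, because a 1.6-fold lower number from compound 1 to compound 2 (0.21 log units; within the scatter) is small. Starting from compound 3, the step to compound 4 is therefore expected to be small as well, a 1.3-fold lower number from compound 3 to compound 4 (0.10 log units; within the scatter), with wide uncertainty since the surroundings of the new group differ. Compound 4 is estimated at 30000 nM, between 12000 nM and 75000 nM.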

Compound 4, concentration for 50% growth inhibition: 23600 nM
Compound 4: middle estimate off by 1.3-fold (0.10 log units), on the high side; low and high end bracket the measured number.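

In this assay, putting methoxy in place of hydrogen on the benzoyl part of compound 3 gave a 1.6-fold lower number from compound 3 to compound 4 (0.21 log units; within the scatter). Set beside the earlier example of this change, the step looks the same on both cores: the same change on two cores in this assay, a 1.6-fold lower number (0.21 log units; within the scatter) from compound 1 to compound 2 and a 1.6-fold lower number (0.21 log units; within the scatter) from compound 3 to compound 4, 1.0-fold (0.00 log units) apart, within the scatter of two such steps. Going by these compounds alone, this agreement shows only that the change stayed small on each of the two cores; with both steps inside the scatter, it does not show a real gain in growth inhibition that travels from one core to the other, and it is not a strict test of transfer either, as the new methoxy in compound 4 sits ortho to a large group while the one in compound 2 sits elsewhere.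

The compounds shown leave open whether a different group in that place, such as an amine or a carboxylic acid, would give a step beyond the scatter on either core. They also leave open whether a methoxy placed ortho to a large group on the core of compound 1 would give the same small step, which would compare the two cores with the new group in one and the same place.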